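Compound 3 Loses Its Acetoxy Group

The source may report more compounds than this note shows. Statements on the series, on what has been measured and on what is new or still open speak of the compounds shown alone.

In a functional assay on V79-379A cells (Cricetulus griseus) for cytotoxicity, read by MTT assay, in the presence of a further agent that is not named here (a higher number here means a weaker inhibitor, a lower number a stronger inhibitor), compound 3 (`COC1=CC(=O)c2c(c(COC(C)=O)c(C)n2C)C1=O`) gives 2500 nM as its reading. Compound 1 (`COC1=CC(=O)c2c(c(COC(=O)c3ccccc3F)c(C)n2C)C1=O`) gives 2000 nM in the same test, and the two sit together, with a 1.3-fold higher number from compound 1 to compound 3 (0.10 log units; within the scatter) separating them. Compound 2 (`COC1=CC(=O)c2c(c(COC(=O)c3ccccc3)c(C)n2C)C1=O`) stands apart at 200 nM as its reading, and the return to the smaller ester is a 13-fold higher number from compound 2 to compound 3 (1.10 log units; beyond the scatter) in size.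

Compound 4 (`COC1=CC(=O)c2c(c(Cc3cc(F)ccc3O)c(C)n2C)C1=O`) carries 5-fluoro-2-hydroxyphenyl in place of acetoxy on a saturated chain carbon bound to an aromatic carbon. Among the measured compounds shown here, no measured step removes the ester, so the evidence is indirect. An aromatic ring entering in place of methyl gave two different outcomes: a 1.3-fold higher number from compound 1 to compound 3 (0.10 log units; within the scatter) when read from the fluorinated compound 1, and a 13-fold higher number from compound 2 to compound 3 (1.10 log units; beyond the scatter) when read from the unsubstituted compound 2. Fluoro itself accounts for a 10-fold lower number from compound 1 to compound 2 (1.00 log units; beyond the scatter) in this small set, which shows that a single aromatic substituent can matter here. These steps point in no single direction, so no shift beyond the scatter is expected, though the uncertainty is wide.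

The expected step is a 1.3-fold lower number from compound 3 to compound 4 (0.10 log units; within the scatter) on this reasoning. For compound 4 the estimated value is 2000 nM in this assay and the expected range runs from 400 nM to 10000 nM as its bounds.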

Compound 4, half-maximal inhibitory concentration: 110000 nM
The estimate for compound 4 lay 55-fold (1.74 log units) below the measured number; measured number outside the range, above it.
By their numbers in this assay, from the lowest: compound 2; then compounds 1 and 3 (each within the scatter of the next); then compound 4.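

Compound 4 is the only compound shown without an ester on the saturated chain carbon bound to an aromatic carbon, and in this assay placing 5-fluoro-2-hydroxyphenyl there in place of acetoxy gives a 44-fold higher number from compound 3 to compound 4 (1.64 log units; beyond the scatter). This shows that the position tolerates less than the esters alone suggested: they differ among themselves, with compound 2 at 200 nM and compound 3 at 2500 nM, but all three stay well short of the number for compound 4. An aromatic ring at this position therefore does not by itself bring the low number of compound 2, whose phenyl stands on a carbonyl carbon, and no measurement shown here accounts for the size of this step.

The compounds shown do not separate the loss of the ester from the entry of the ring, or the part of the fluoro from that of the hydroxyl on that ring. Also open, on these data alone, is where an unsubstituted phenyl, a free hydroxyl, an amine or a longer ester chain on the same carbon would fall.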